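A few compounds are considered here, and "the series" means these few. Any claim that something is new, unique, unknown or untested is made for them only; others in the source may bear on it.

Working notes on the series.

Within the data shown here, compound 1 `CNc1nc(N)nc2c1ncn2/C=C1/CC1(CO)CO` holds the only numerical reading in an ADME assay on BCBL1 cells (Homo sapiens) for cytotoxicity, with a stated time of 7 days; a higher number here means that more compound is tolerated, a lower number that less compound is tolerated: in this assay compound 1 gives 67000 nM. Among the measured compounds shown here, compound 2 `COCCOc1nc(N)nc2c1ncn2/C=C1/CC1(CO)CO` is the single measured neighbour, differing by 2-methoxyethoxy in place of methylamino on an aromatic carbon. In this assay compound 2 is reported only as a limit, > 20000 nM. For the measured compounds named here, the one measured step, a step that the limit leaves unreadable from compound 1 to compound 2, is therefore of unreadable size; it neither supports nor rules out a change beyond the scatter. The same point is made by the limit of > 20000 nM in this assay, at which 1 of the 2 values shown sits.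

Compound 3 `Nc1nc(OCc2ccccc2)c2ncn(/C=C3/CC3(CO)CO)c2n1` is not yet measured in this assay. It differs from compound 1 as follows: benzyloxy in place of methylamino on an aromatic carbon

Going by the values given here, the only measured step touches the same aromatic carbon, yet its size cannot be read, so no direction can be argued from it. With nothing beyond the scatter demonstrated at this position, compound 3 is expected to sit close to compound 1, estimated at 45000 nM with a range of 12000 nM to 150000 nM in this assay. This estimate corresponds to an expected step of a 1.5-fold lower number from compound 1 to compound 3 (0.17 log units; within the scatter) that is within the usual scatter.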

Compound 3, half-maximal cytotoxic concentration: > 20000 nM
Compound 3: no number, only a limit; the forecaster's own chance of this, stated with the estimate: 40%; the middle value is on the limit's open side.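

Among these compounds, compound 3 is reported in this assay only as a limit, > 20000 nM, so no step from compound 1 or compound 2 to compound 3 can be read: the limit of > 20000 nM in this assay, at which 2 of the 3 values shown sit.

The compounds shown leave open whether benzyloxy or 2-methoxyethoxy in place of methylamino shifts the value in this assay beyond the scatter, and how compound 2 and compound 3 compare.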